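A Furan Ring Replaces the Chain End of Compound 2

A few compounds are considered here, and "the series" means these few. Any claim that something is new, unique, unknown or untested is made for them only; others in the source may bear on it.

In a functional assay on Detroit 98 cells (Homo sapiens) for inhibition (a higher number here means that more compound is needed for the effect, a lower number that less compound is needed), compound 1 `NNc1ncnc2c1cnn2C1O[C@H](CO)[C@@H](O)[C@H]1O` gives 20 uM, while compound 2 `CC(C)=CCNc1ncnc2c1cnn2C1O[C@H](CO)[C@@H](O)[C@H]1O` gives 1.5 uM, the lower of the two numbers. Compound 3 `OC[C@H]1OC(n2ncc3c(NCc4ccco4)ncnc32)[C@H](O)[C@@H]1O` has furan-2-yl in place of 2-methylprop-1-en-1-yl on a saturated chain carbon bound to a nitrogen on an aromatic ring. For the measured compounds named here, the only measured step, a 13-fold lower number from compound 1 to compound 2 (1.12 log units; beyond the scatter), put 3-methylbut-2-en-1-yl in place of amino, which is a different change. Compound 3 keeps a chain on that nitrogen, so only a modest shift is expected, in either direction. The expected step is a 1.3-fold higher number from compound 2 to compound 3 (0.12 log units; within the scatter). For compound 3 the estimated value is 2 uM, with an expected range of 0.6 uM to 8 uM.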

Compound 3, concentration for half-maximal effect: 0.3 uM
Compound 3: middle estimate off by 6.7-fold (0.82 log units), on the high side; the measured number lies below the stated range.
By their numbers in this assay, from the lowest: compound 3; then compound 2; then compound 1.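

Furan-2-yl in place of 2-methylprop-1-en-1-yl gives a 5.0-fold lower number from compound 2 to compound 3 (0.70 log units; beyond the scatter) in this assay, so the end of the chain on this nitrogen still shifts the number beyond the scatter, and having a chain there is not the whole story. (Furan-2-yl)methyl in place of amino gives a 67-fold lower number from compound 1 to compound 3 (1.82 log units; beyond the scatter), the largest step among these compounds. Nothing available explains why the furan-bearing chain gives the lower number.

From the compounds shown here alone, it remains open whether the ring itself or its oxygen matters. Phenyl or thiophen-2-yl at the same place would help separate the two.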